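This account rests on a few compounds, and the source may have more. Where it says the series, first, only, none or still open, it means among the compounds named here.

The measured compounds and their values:

compound 1 `COc1cc(-c2cc(/C=C/C(=O)c3ccc(N)cc3)[nH]n2)cc(OC)c1OC` with 3680 nM
compound 2 `COc1cc(-c2cc(/C=C/C(=O)c3ccc(Cl)c(Cl)c3)[nH]n2)cc(OC)c1OC` with 2530 nM
compound 3 `COc1ccc(C(=O)/C=C/c2cc(-c3cc(OC)c(OC)c(OC)c3)n[nH]2)cc1OC` with "not determined" (no result reported)

The study reports a functional assay on HOP-92 cells (Homo sapiens) for inhibition, read by sulforhodamine B assay, with a stated time of 48 h (on this read-out lower numbers stand for stronger inhibition of growth and higher numbers for weaker inhibition of growth), for two of the three compounds. In this assay compound 1 gives 3680 nM and compound 2 gives 2530 nM. Within the data shown here, the only measured step, a 1.5-fold lower number from compound 1 to compound 2 (0.16 log units; within the scatter), is a change at the aryl ketone end of the shared core and is within the scatter. Compound 3 carries the aryl ketone on the other side of its core and has no number in this assay, so there is nothing measured to place it against the others.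

The step to compound 4 `COc1ccc(C(=O)/C=C/c2cc(-c3cc(OC)c(OC)c(OC)c3)n[nH]2)cc1` is hydrogen in place of methoxy on an aromatic carbon, a change at the aryl ketone end of the core of compound 3. The change from compound 1 to compound 2 also sits on the aryl ketone ring, but it swaps different groups on a core arranged the other way, so it bears on this step only loosely, and it was small in any case. Among the measured compounds shown here, no measured step addresses the loss of a methoxy group. With compound 3 unmeasured and the two numbers in this assay lying close together, no direction beyond the scatter is expected for compound 4.

Compound 4 is therefore expected to give about 3000 nM in this assay, with a wide range from 700 nM to 13000 nM.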

Compound 4, concentration for 50% growth inhibition: 1060 nM
For compound 4 the middle estimate is 2.8-fold (0.45 log units) above the measured one; low and high end bracket the measured number.
By their numbers in this assay, from the lowest: compound 4; then compounds 2 and 1 (each within the scatter of the next).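

In this assay, 4-methoxyphenyl in place of 3,4-dichlorophenyl on the carbonyl carbon gives a 2.4-fold lower number from compound 2 to compound 4 (0.38 log units; beyond the scatter), and methoxy in place of amino on an aromatic carbon gives a 3.5-fold lower number from compound 1 to compound 4 (0.54 log units; beyond the scatter), so both changes at the aryl ketone end reach beyond the scatter. Among these compounds, the earlier step between compound 1 and compound 2 stayed within the scatter, so these are the first measured changes at this end that can be told apart from it, and compound 4 now has the lowest number of the three measured compounds. No evidence at hand bears on what lies behind these steps.

As far as these compounds go, compound 3 has no result in this assay, so the change from 3,4-dimethoxyphenyl to 4-methoxyphenyl cannot be read, and the part played by the departing methoxy group stays unknown. From the compounds shown here alone, it also remains open how compound 4 would compare with a close relative carrying a hydroxy group, an ethoxy group or a fluorine atom in place of its methoxy group on this ring.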